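Dithiocarbamate swap at a thiocarbonyl carbon, second case

The source may hold more compounds than are shown below. What is called first, only, known or untested is meant among the compounds shown, and "the series" means these compounds.

The set holds three measured compounds and one still to be measured. Compound 1 `S=C(SCc1nc2ccccc2[nH]1)N1CCOCC1` and compound 2 `CN(C)C(=S)SCc1nc2ccccc2[nH]1` share one core; compound 3 `O=C(CC(SC(=S)N1CCOCC1)c1ccccc1)c1ccccc1` and compound 4 `CN(C)C(=S)SC(CC(=O)c1ccccc1)c1ccccc1` share another. How the two cores differ is not broken down here. In a functional assay on the whole organism for inhibition, with Cicer arietinum as the target, with a stated time of 7 days (a lower number here means a stronger inhibitor, a higher number a weaker inhibitor), compound 1 gives 1890 nM, compound 2 gives 2120 nM, and compound 3 gives 1650 nM. Within this set, compound 3 carries the lowest number, but its gaps to compound 1 and compound 2 are both within the scatter, so no order among the three can be read from these values.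

One structural change is made twice. From compound 1 to compound 2 it is dimethylamino in place of morpholin-4-yl on a thiocarbonyl carbon, and the step it made was a 1.1-fold higher number from compound 1 to compound 2 (0.05 log units; within the scatter). From compound 3 to compound 4 it is dimethylamino in place of morpholin-4-yl on a thiocarbonyl carbon, the same change, on a thiocarbonyl carbon whose other neighbour is sulfur in both cases. Among the compounds with values here, the only guide to what this change does in this assay is the one measured instance, which stayed within the scatter.

Compound 4 is therefore expected to stay close to compound 3, with an estimated step of a 1.1-fold higher number from compound 3 to compound 4 (0.04 log units; within the scatter), because a 1.1-fold higher number from compound 1 to compound 2 (0.05 log units; within the scatter) showed no real movement for the same change. The expectation rests on a single precedent on a different core, so the range is kept wide. Compound 4 is estimated at 1800 nM, with a likely span from 1100 nM to 3000 nM.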

Compound 4, half-maximal inhibitory concentration: 2430 nM
Compound 4: middle estimate off by 1.4-fold (0.13 log units), on the low side, and the stated range covers the measured number.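

In this assay, within the data shown here, the swap of morpholin-4-yl for dimethylamino on a thiocarbonyl carbon gave a 1.5-fold higher number from compound 3 to compound 4 (0.17 log units; within the scatter), so on this second core too the change produced no step that can be told apart from repeat measurement. Set beside the earlier case, the two steps agree as far as these measurements can tell: the same change on two cores in this assay, a 1.1-fold higher number (0.05 log units; within the scatter) from compound 1 to compound 2 and a 1.5-fold higher number (0.17 log units; within the scatter) from compound 3 to compound 4, 1.3-fold (0.12 log units) apart, within the scatter of two such steps. Among these compounds, this shows that the swap left the number without real movement on both cores, but it does not show that the two cores respond identically, and with only two pairs, neither giving a step beyond the scatter, it says nothing about how the swap would behave on any further core.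

The compounds shown leave open whether any other group on the thiocarbonyl carbon, such as piperidin-1-yl, diethylamino or piperazin-1-yl, would move the number beyond the scatter on either core. Among the compounds shown here, they also leave open whether a longer chain on the amine, or a carboxylic acid carried on that chain, would do so, as morpholin-4-yl and dimethylamino are the only two groups compared here.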